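A few compounds are considered here, and "the series" means these few. Any claim that something is new, unique, unknown or untested is made for them only; others in the source may bear on it.

In a functional assay on NCI-H460 cells (Homo sapiens) for inhibition (on this read-out higher numbers stand for weaker inhibition and lower numbers for stronger inhibition), compound 2 `COc1cc(-n2cncc2-c2ccc3[nH]ccc3c2)cc(OC)c1OC` gives 540 nM, while compound 1 `COc1cc(-n2ccnc2-c2ccc(N(C)C)cc2)cc(OC)c1OC` gives 270 nM, a gap within the usual scatter. Compound 3 `COc1ccc(-c2cncn2-c2cc(OC)c(OC)c(OC)c2)cc1O`, at 61 nM, inhibits clearly more strongly than compound 2 does. Compound 4 `COc1cc(-n2cncc2-c2ccc3c(ccn3C)c2)cc(OC)c1OC` differs from compound 2 in one place: methyl in place of hydrogen on an aromatic nitrogen. Among the measured compounds shown here, no measured pair shows this change alone, so its size cannot be read directly from the data. The only hint is how far the number moves within this small set, reaching 61 nM for compound 3. The step expected in this assay is a 4.5-fold lower number from compound 2 to compound 4 (0.65 log units; beyond the scatter), towards stronger inhibition, though a step within the scatter remains possible. For compound 4 the estimated value is 120 nM, with an expected range of 20 nM to 600 nM.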

Compound 4, half-maximal inhibitory concentration: 19 nM
The estimate for compound 4 lay 6.3-fold (0.80 log units) above the measured number; the measured number lies below the stated range.
By their numbers in this assay, from the lowest: compound 4; then compound 3; then compounds 1 and 2 (each within the scatter of the next).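

In this assay, methyl in place of hydrogen on the aromatic nitrogen gives a 28-fold lower number from compound 2 to compound 4 (1.45 log units; beyond the scatter), a large move towards stronger inhibition. Compound 4 therefore shows that this nitrogen does not need its hydrogen for strong inhibition here, and that a single added carbon at this position can change the result greatly. Nothing available explains this gain. Going by these compounds, whether a longer chain such as ethyl, or an amine-bearing chain, on the same nitrogen would keep the gain stays open.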